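A few compounds are considered here, and "the series" means these few. Any claim that something is new, unique, unknown or untested is made for them only; others in the source may bear on it.

Measured so far in a functional assay for inhibition of sodium/hydrogen exchanger (Oryctolagus cuniculus); a higher number here means a weaker inhibitor, a lower number a stronger inhibitor:

compound 1, `Cc1cc(-c2ccco2)c(S(C)(=O)=O)cc1C(=O)N=C(N)N` — 16 nM
compound 2, `Cc1cc(Oc2ccccc2)c(S(C)(=O)=O)cc1C(=O)N=C(N)N` — 10 nM

Among the compounds with values here, compound 2 gives the lowest of the two numbers in this assay; its nearest neighbour is compound 1, and the only step between measured compounds, a 1.6-fold lower number from compound 1 to compound 2 (0.20 log units; within the scatter), stays within the scatter. The series therefore holds no change in this assay that can be told apart from repeat measurement.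

Compound 3, `Cc1cc(-n2cccn2)c(S(C)(=O)=O)cc1C(=O)N=C(N)N`, is not yet measured. It differs from compound 2 as follows: 1H-pyrazol-1-yl in place of phenoxy on an aromatic carbon.

Within the data shown here, only one measured step bears on a swap at this position, namely a 1.6-fold lower number from compound 1 to compound 2 (0.20 log units; within the scatter), where furan-2-yl gave way to phenoxy without a change beyond the scatter. Nothing measured speaks to 1H-pyrazol-1-yl itself, so the expectation rests on that single step alone. Among the measured compounds shown here, no step beyond the scatter is expected in this assay; the estimated step is a 1.5-fold higher number from compound 2 to compound 3 (0.18 log units; within the scatter), with a wide range to reflect the single precedent.

Compound 3 is estimated at 15 nM, expected between 5 nM and 45 nM.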

Compound 3, half-maximal inhibitory concentration: 25 nM
Compound 3: the middle estimate sits 1.7-fold (0.22 log units) below what was measured, within the range that was stated.
By their numbers in this assay, from the lowest: compounds 2, 1 and 3 (each within the scatter of the next, the first and the last beyond it).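

In this assay this position now shows its first step beyond the scatter: a 2.5-fold higher number from compound 2 to compound 3 (0.40 log units; beyond the scatter) is a modest change that comes with 1H-pyrazol-1-yl in place of phenoxy, on the aromatic carbon ortho to the methylsulfonyl group. The swap from furan-2-yl tells a different story, since a 1.6-fold higher number from compound 1 to compound 3 (0.19 log units; within the scatter) stays within the scatter and leaves those two groups indistinguishable here, so only phenoxy and 1H-pyrazol-1-yl are separated, and only narrowly. No supporting data are available to account for that separation.

The compounds shown carry only ring substituents at this position, so it remains open how a dimethylamino group, a carboxylic acid or a longer alkyl chain would read in this assay on the same core. Also open, on these data alone, is whether the modest separation of phenoxy from 1H-pyrazol-1-yl would persist if the methyl group were replaced by a chlorine atom, or the methylsulfonyl group by a nitrile.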